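The source may report more compounds than this note shows. Statements on the series, on what has been measured and on what is new or still open speak of the compounds shown alone.

In a functional assay on P388 cells (Mus musculus) for cytotoxicity (on this read-out higher numbers stand for weaker inhibition and lower numbers for stronger inhibition), compound 1 `COc1ccc2cc1Oc1ccc(cc1)C[C@H]1C(=O)N(C)[C@@H](C2)C(=O)N[C@H](C)C(=O)N[C@@H](C)C(=O)N(C)[C@@H](Cc2ccccc2)C(=O)N[C@@H](C)C(=O)N1C` gives 295 nM, while compound 2 `CCN1C(=O)[C@@H](C)NC(=O)[C@@H]2Cc3ccc(OC)c(c3)Oc3ccc(cc3)C[C@@H](C(=O)N2C)N(C)C(=O)[C@H](C)NC(=O)[C@H](Cc2ccc(OC)cc2)N(C)C(=O)[C@@H]1C` gives 43.7 nM, the lower of the two numbers by a margin beyond the scatter. Compound 3 `CCCCN1C(=O)[C@@H](C)NC(=O)[C@@H]2Cc3ccc(OC)c(c3)Oc3ccc(cc3)C[C@@H](C(=O)N2C)N(C)C(=O)[C@H](C)NC(=O)[C@H](Cc2ccc(OC)cc2)N(C)C(=O)[C@@H]1C` has not yet been measured. It departs from compound 2 by ethyl in place of hydrogen on a saturated chain carbon, two bonds along the chain from an amide-type nitrogen in a ring, with ethyl in place of hydrogen on a saturated chain carbon, two bonds along the chain from an amide-type nitrogen in a ring. For the measured compounds named here, no measured single-place step is available as a guide. A small weakening is expected, an estimated 2.3-fold higher number from compound 2 to compound 3 (0.36 log units; beyond the scatter). The expected value for compound 3 is 100 nM, within a range of 30 nM to 350 nM.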

Compound 3, half-maximal inhibitory concentration: 12 nM
Estimate against measurement, compound 3: 8.3-fold (0.92 log units) above, and the stated range ends above it.
By their numbers in this assay, from the lowest: compound 3; then compound 2; then compound 1.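

In this assay, going from ethyl to butyl at this position gives a 3.6-fold lower number from compound 2 to compound 3 (0.56 log units; beyond the scatter) and so moves toward stronger inhibition. For the compounds shown here, this is the first single-place step available, and it shows that the position on a saturated chain carbon, two bonds along the chain from an amide-type nitrogen in a ring, tolerates two more carbons and responds to them. Nothing measured here accounts for the gain. On these data alone, whether a longer chain such as hexyl would extend this gain remains open. So does the effect of ending the chain in an amine or a carboxylic acid.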